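Extending the Side Chain of a Cyclohexyl Carbamate

The compounds below may be only part of what the source reports. "The series", "measured", "known", "first", "only" and "open" are said of these compounds alone.

Two cyclohexyl carbamates have been measured in an assay for binding affinity to Fatty-acid amide hydrolase 1 (Rattus norvegicus); a higher number here means a weaker inhibitor, a lower number a stronger inhibitor. Compound 1 `Cc1cccc(OC(=O)NC2CCCCC2)c1` gives 813 nM in this assay, the higher of the two numbers. Compound 2 `O=C(NC1CCCCC1)Oc1ccc2cccc(Br)c2c1` gives 174 nM in this assay, a lower number, and the gap between the two lies beyond the usual scatter. With only these two points, no trend across a series can be claimed.

Compound 3 `CCCCCc1cccc(OC(=O)NC2CCCCC2)c1` has not yet been measured. It differs from compound 1 in one place: butyl in place of hydrogen on a saturated chain carbon bound to an aromatic carbon. The same difference, cut one bond further out, reads methyl to pentyl on the aromatic ring of the shared core.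

Among the compounds with values here, no measured pair here shows this exact change, so the expectation rests on the two values alone. Compound 3 is expected to give a lower number than compound 1 in this assay, with the step from a 5.4-fold lower number from compound 1 to compound 3 (0.73 log units; beyond the scatter) estimated at a size clearly beyond the scatter. Compound 3 is therefore estimated at 150 nM in this assay, within a range from 40 nM to 600 nM.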

Compound 3, half-maximal inhibitory concentration: 186 nM
Compound 3: middle estimate off by 1.2-fold (0.09 log units), on the low side; the range from low to high includes it.
By their numbers in this assay, from the lowest: compounds 2 and 3 (each within the scatter of the next); then compound 1.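

Among these compounds, this is the only measured pair that differs in one place, and so the first direct reading of a change at this position. In this assay, butyl in place of hydrogen on a saturated chain carbon bound to an aromatic carbon gives a 4.4-fold lower number from compound 1 to compound 3 (0.64 log units; beyond the scatter), a change that lies beyond the scatter, so extending methyl to pentyl on the shared core is accompanied by stronger inhibition rather than a loss of it. Nothing measured here accounts for that step, which therefore stands as an observation without an explanation.

A single step cannot show how the number follows chain length, and ethyl, propyl and butyl in place of the methyl of compound 1, or a longer chain such as heptyl or octyl, would be needed to tell whether the trend is steady or whether it levels off or reverses. As far as these compounds go, it is also open whether the same position would keep the lower number with a chain ending in an amine, a carboxylic acid or a phenyl ring.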